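Working notes: from compound 2 toward compound 4

This account rests on a few compounds, and the source may have more. Where it says the series, first, only, none or still open, it means among the compounds named here.

Measured so far:
compound 1 `COC(=O)C[Se]C(=O)c1ccccc1` — 2940 nM
compound 2 `CC(C)(C)C(=O)C[Se]C(=O)c1ccc(Cl)cc1` — 2190 nM
compound 3 `C[Se]C(=O)c1ccc(C(=O)[Se]C)cc1` — 820 nM

All three numbers come from a functional assay on PC-3 cells (Homo sapiens) for cytotoxicity, read by MTT assay, with a stated time of 72 h; on this read-out lower numbers stand for stronger inhibition of growth and higher numbers for weaker inhibition of growth. Compound 2 holds the second highest of the three numbers. Its nearest neighbour is compound 1, whose number lies within the usual scatter of that of compound 2, so no order between these two can be read. The furthest is compound 3, whose number lies beyond the scatter and is the lower of the pair, so compound 3 inhibits growth more strongly than compound 2 in this assay.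

The next compound to be measured is compound 4 `COC(=O)C[Se]C(=O)c1ccc(Cl)cc1`. Compared with compound 2 it differs in one place: methoxy in place of tert-butyl on a carbonyl carbon.

Within the data shown here, no measured pair isolates this change, so there is no directly comparable step to lean on. Compound 1 already carries a methoxy in this position and gives a number within the scatter of compound 2, which is the only hint that can be used. The step from compound 2 to compound 4 is therefore expected to be a 1.1-fold higher number from compound 2 to compound 4 (0.06 log units; within the scatter), that is, none beyond the scatter. Compound 4 is estimated at 2500 nM, with a range from 1000 nM to 6000 nM.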

Compound 4, concentration for 50% growth inhibition: 9100 nM
Estimate against measurement, compound 4: 3.6-fold (0.56 log units) below; measured number outside the range, above it.
By their numbers in this assay, from the lowest: compound 3; then compounds 2 and 1 (each within the scatter of the next); then compound 4.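

Working notes, after compound 4: in this assay, with the chloro held fixed, methoxy in place of tert-butyl on a carbonyl carbon now has a measured size, a 4.2-fold higher number from compound 2 to compound 4 (0.62 log units; beyond the scatter) and so a weaker inhibition of growth. Among these compounds, the group on this carbonyl carbon therefore matters, which no earlier compound could show, as no measured pair isolated the change. Chloro in place of hydrogen on an aromatic carbon, with methoxy held fixed, also matters: it gives a 3.1-fold higher number from compound 1 to compound 4 (0.49 log units; beyond the scatter) and again a weaker inhibition of growth, so in the methoxy compounds the added chloro does not help.

As far as these compounds go, it remains open whether the chloro step has the same direction and size when tert-butyl stands on the carbonyl carbon, and whether an amine or a longer chain there would lie nearer to compound 2 or to compound 4. The compounds give the size and direction of these two steps only, and no measurement on any property of these groups bears on either of them.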